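Swapping Dimethylamino for Diethylamino on the Side Chain

The source may hold more compounds than are shown below. What is called first, only, known or untested is meant among the compounds shown, and "the series" means these compounds.

Compound 1 `Cc1cc(NCCN(C)C)nc2ccc(NC(=O)c3ccc(Cl)c(Cl)c3)cc12` is assessed in a functional assay on MCF7 cells (Homo sapiens) for antiproliferative activity, read by MTT assay, with a stated time of 72 h (on this read-out lower numbers stand for stronger inhibition and higher numbers for weaker inhibition), where compound 1 gives 2550 nM. Two other compounds share its core. Compound 2 `CCN1CCN(c2cc(C)c3cc(NC(=O)c4cc(Cl)cc(Cl)c4)ccc3n2)CC1` gives 6090 nM in this assay, and compound 3 `CCN1CCN(c2cc(C)c3cc(NC(=O)c4cc5ccccc5[nH]4)ccc3n2)CC1` gives 2950 nM. Against these, compound 1 stands with compound 3 inside the usual scatter, while compound 2 returns a number beyond the scatter above both. For the measured compounds named here, the only single-point step among the measured compounds is a 2.1-fold lower number from compound 2 to compound 3 (0.31 log units; beyond the scatter), a change on the carbonyl carbon that does not touch the side chain.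

Compound 4 `CCN(CC)CCNc1cc(C)c2cc(NC(=O)c3ccc(Cl)c(Cl)c3)ccc2n1` differs from compound 1 only in the side chain: diethylamino in place of dimethylamino on a saturated chain carbon, two bonds along the chain from a nitrogen on an aromatic ring. Going by the values given here, no measured pair isolates this change, so nothing among the known values speaks directly to it; the one step recorded concerns a different part of the molecule. Compound 4 is therefore expected to show no step beyond the scatter, with a 1.1-fold higher number from compound 1 to compound 4 (0.02 log units; within the scatter) as the anticipated outcome. The estimate for compound 4 in this assay is 2700 nM, with a range from 1000 nM to 7500 nM.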

Compound 4, half-maximal inhibitory concentration in the MCF7 assay: 1420 nM
Beside the measured number, compound 4's estimate is 1.9-fold (0.28 log units) above it, and the stated range covers the measured number.
By their numbers in the MCF7 assay, from the lowest: compounds 4, 1 and 3 (each within the scatter of the next, the first and the last beyond it); then compound 2.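

For the compounds shown here, in the MCF7 assay the side chain is now tested on its own for the first time: compound 1 gives 2550 nM and compound 4 gives 1420 nM, and diethylamino in place of dimethylamino gives a 1.8-fold lower number from compound 1 to compound 4 (0.25 log units; within the scatter), so this change on the saturated chain carbon does not move the number past the scatter. In a physicochemical assay for lipophilicity, at pH 7.4 (a higher number here means a more lipophilic compound, a lower number a more polar compound), compound 1 gives 1.47 and compound 4 gives 1.66, and the same change gives a number 0.19 log units higher from compound 1 to compound 4 (within the scatter), so a single pair at this position stays inside the scatter on both read-outs. No supporting evidence bears on these two results.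

The compounds shown leave open how a longer chain between the two nitrogens, or a pyrrolidine in place of diethylamino, would read in the MCF7 assay. They also leave open whether the diethylamino change would give a similar step with 1H-indol-2-yl on the carbonyl carbon.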